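A few compounds are considered here, and "the series" means these few. Any claim that something is new, unique, unknown or untested is made for them only; others in the source may bear on it.

Compound 1 `Cc1ccc2nc(Nc3nc(Nc4ccc(S(N)(=O)=O)cc4)ncc3F)sc2c1` gives 6390 nM in a functional assay on MDA-MB-231 cells (Homo sapiens) for antiproliferative activity, read by MTT assay, with a stated time of 48 h; on this read-out lower numbers stand for stronger inhibition and higher numbers for weaker inhibition.
Compound 2 `Cc1ccc2nc(Nc3nc(Nc4ccc(S(N)(=O)=O)cc4)ncc3C)sc2c1` gives 9080 nM.
Compound 3 `COc1cccc(Nc2ncc(C)c(Nc3nc4ccccc4s3)n2)c1` gives only > 50000 nM, a limit of this assay.

Compound 2 has the highest of the two numbers; its nearest neighbour is compound 1, and the step of a 1.4-fold higher number from compound 1 to compound 2 (0.15 log units; within the scatter) lies within the scatter. Compound 4 `Cc1cnc(Nc2ccc(S(N)(=O)=O)cc2)nc1Nc1nc2ccc(Cl)cc2s1` differs from compound 2 by chloro in place of methyl on an aromatic carbon. Within the data shown here, no measured step bears directly on this change; the only step available, a 1.4-fold higher number from compound 1 to compound 2 (0.15 log units; within the scatter), concerns a different ring and was small, so no step beyond the scatter is expected in this assay. Compound 4 is therefore estimated at 7000 nM, with a range from 2500 nM to 20000 nM, meaning an expected step of a 1.3-fold lower number from compound 2 to compound 4 (0.11 log units; within the scatter).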

Compound 4, half-maximal inhibitory concentration: 9420 nM
Compound 4: middle estimate off by 1.3-fold (0.13 log units), on the low side; the measured number falls inside the stated range.
By their numbers in this assay, from the lowest: compounds 1, 2 and 4 (each within the scatter of the next). At a limit, above all of these: compound 3.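

In this assay, chloro in place of methyl on the six-membered aromatic ring of carbon only, part of the fused system, gives a 1.0-fold higher number from compound 2 to compound 4 (0.02 log units; within the scatter). Among these compounds, the earlier step concerned a different ring, so this is the only reading at this position, and here the two groups cannot be told apart. Nothing shown offers an explanation for this result.

Going by these compounds, whether an amine or a carboxylic acid at this place would move the number beyond the scatter stays open. So does whether the same exchange would read alike with fluoro rather than methyl on the other ring.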